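This account rests on a few compounds, and the source may have more. Where it says the series, first, only, none or still open, it means among the compounds named here.

Measured so far:
- compound 1 `Cc1cc(NC(=O)Cn2nnc(-c3ccccc3)n2)n(C2CCS(=O)(=O)C2)n1`, which in an assay on HEK293 cells for activation of Kir3.1/Kir3.2 (Homo sapiens), read by thallium flux (a lower number here means that less compound is needed, a higher number that more compound is needed for the effect), gives 1030 nM
- compound 2 `Cc1cc(NC(=O)Cn2nnc(-c3cccnc3)n2)n(C2CCCCC2)n1`, which in this assay gives 1930 nM

Compound 2 holds the higher of the two numbers, yet compound 1, its nearest neighbour, sits within the usual scatter, so the two cannot be ranked. The next compound is compound 3 `Cc1cccc(-c2nnn(CC(=O)Nc3cc(C)nn3C3CCCCC3)n2)c1`. It differs from compound 2 in one place: 3-methylphenyl in place of pyridin-3-yl on an aromatic carbon. Within the data shown here, no pair of measured compounds covers this change, so its size is open. Since compound 1 and compound 2 lie within the scatter of each other, a small step in this assay is expected, if anything toward a lower number. Compound 3 is estimated at 1200 nM, with a range from 400 nM to 3500 nM. This amounts to an expected step of a 1.6-fold lower number from compound 2 to compound 3 (0.21 log units; within the scatter).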

Compound 3, half-maximal effective concentration: 129 nM
Compound 3: middle estimate off by 9.3-fold (0.97 log units), on the high side; measured number outside the range, below it.
By their numbers in this assay, from the lowest: compound 3; then compounds 1 and 2 (each within the scatter of the next).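

Placing 3-methylphenyl instead of pyridin-3-yl on the aromatic carbon of the five-membered aromatic ring with 4 nitrogen gives a large step in this assay: a 15-fold lower number from compound 2 to compound 3 (1.17 log units; beyond the scatter). This shows that the assay responds strongly to the group at this position, which compound 1 and compound 2, differing in more than one place, could not show. Nothing at hand bears on the reason for this step.

As far as these compounds go, the change swaps the ring nitrogen for carbon and adds the methyl at once, so their separate shares remain open. Also open, from the compounds shown here alone, is how a 4-methylphenyl or 3-methoxyphenyl group would read at this position.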